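Moving the isopropyl group around the phenoxy ring

This account rests on a few compounds, and the source may have more. Where it says the series, first, only, none or still open, it means among the compounds named here.

Measured compounds:
Compound 1, `CO[C@H]1O[C@H](COc2ccc(OC3CCCCC3)cc2)[C@@H](O)[C@H](O)[C@H]1Oc1ccc(C(C)C)cc1`: 27000 nM
Compound 2, `CO[C@H]1O[C@H](COc2ccc(-c3ccccc3)cc2)[C@@H](O)[C@H](O)[C@H]1Oc1ccccc1`: 36000 nM
Compound 3, `CO[C@H]1O[C@H](COc2ccc(-c3ccccc3)cc2)[C@@H](O)[C@H](O)[C@H]1Oc1ccccc1C(C)C`: 33000 nM

All three were tested in a functional assay on A549 cells (Homo sapiens) for cytotoxicity, read by MTT assay, with a stated time of 48 h; a lower number here means that less compound is needed, a higher number that more compound is needed for the effect. By raw number compound 3 sits in the middle of the three, but the gaps are small: the step of a 1.1-fold lower number from compound 2 to compound 3 (0.04 log units; within the scatter) is within the scatter, and the values of compound 1 and compound 3 also lie within the scatter of each other, so no real separation among them can be claimed.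

The next compound, compound 4, `CO[C@H]1O[C@H](COc2ccc(-c3ccccc3)cc2)[C@@H](O)[C@H](O)[C@H]1Oc1ccc(C(C)C)cc1`, has not yet been measured in this assay. It differs from compound 3 only in where the isopropyl group sits on the phenoxy ring: 4-isopropylphenyl in place of 2-isopropylphenyl on an oxygen on a saturated carbon.

Within the data shown here, only one measured step touches this part of the molecule, a 1.1-fold lower number from compound 2 to compound 3 (0.04 log units; within the scatter), and it shows that adding the isopropyl group at all changed nothing beyond the scatter. Compound 1 carries the same 4-isopropylphenoxy group as compound 4, but with a different group at the far end of the molecule, so its value can only hint that this arrangement is compatible with numbers in the same range.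

A step within the scatter is therefore expected, a 1.1-fold lower number from compound 3 to compound 4 (0.04 log units; within the scatter). Compound 4 is estimated at 30000 nM, likely between 15000 nM and 60000 nM.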

Compound 4, half-maximal effective concentration: 32000 nM
Estimate against measurement, compound 4: 1.1-fold (0.03 log units) below; low and high end bracket the measured number.
By their numbers in this assay, from the lowest: compounds 1, 4, 3 and 2 (each within the scatter of the next).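

In this assay, among these compounds, the position of the isopropyl group on the phenoxy ring can now be read for the first time: 4-isopropylphenyl in place of 2-isopropylphenyl gives a 1.0-fold lower number from compound 3 to compound 4 (0.01 log units; within the scatter) and so stays within the scatter, which means that these two placements cannot be told apart. Compared with the plain phenoxy group, the new compound gives a 1.1-fold lower number from compound 2 to compound 4 (0.05 log units; within the scatter) and this is also within the scatter, so adding isopropyl to the ring leaves the number unchanged in the 4-isopropylphenyl form as well as in the 2-isopropylphenyl form. With the 4-isopropylphenoxy group held constant, phenyl in place of cyclohexyloxy on an aromatic carbon gives a 1.2-fold higher number from compound 1 to compound 4 (0.07 log units; within the scatter) and likewise stays within the scatter, so this change at the far end of the molecule shows no measurable effect either.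

From the compounds shown here alone, all four numbers lie within the scatter of their neighbours, so it remains open whether any change on this ring can move the number at all, for instance an amine or a carboxylic acid in place of the isopropyl group. No measurement shown here explains why these changes leave the number where it is.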